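The source may hold more compounds than are shown below. What is called first, only, known or untested is meant among the compounds shown, and "the series" means these compounds.

Compound 2 `Cc1cccc(N2CCN(C(=O)CN3C(=O)CC(C)C3=O)CC2)c1` stands level with compound 1 `CC1CC(=O)N(CC(=O)N2CCN(c3cccc(Cl)c3Cl)CC2)C1=O` in a functional assay on the whole organism (strain CD1) with Mus musculus as the target, with a stated time of 0.5 h; a lower number here means that less compound is needed, a higher number that more compound is needed for the effect: compound 1 gives 100 mg/kg, and compound 2 gives 100 mg/kg. Going by the values given here, the only step measured so far, no change at the digits printed from compound 1 to compound 2 (within the scatter), left the read-out where it was. Compound 3 `CC1CC(=O)N(CC(=O)N2CCN(c3ccc(Cl)c(Cl)c3)CC2)C1=O` differs from compound 2 by 3,4-dichlorophenyl in place of 3-methylphenyl on an amine nitrogen in a ring. Among the compounds with values here, no measured step places a 3,4-dichlorophenyl on the amine nitrogen in the ring, so the sole guide is the step from compound 1 to compound 2, in which exchanging a dichlorophenyl for a methylphenyl on the amine nitrogen in the ring moved nothing beyond the scatter. On that basis the step from compound 2 to compound 3 is expected to be no change at the digits printed from compound 2 to compound 3 (within the scatter), that is, none beyond the scatter. Compound 3 is accordingly estimated at 100 mg/kg, with a range from 50 mg/kg to 200 mg/kg.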

Compound 3, minimum effective dose: 100 mg/kg
For compound 3 middle estimate and measured number coincide at the digits printed; the range from low to high includes it.
By their numbers in this assay, from the lowest: compounds 1, 2 and 3 (each within the scatter of the next).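

In this assay, the exchange on the amine nitrogen in the ring gives no change at the digits printed from compound 2 to compound 3 (within the scatter), so a second dichlorophenyl group now matches the 3-methylphenyl group. Going by these compounds alone, the two dichlorophenyl groups can also be compared directly for the first time, and 3,4-dichlorophenyl in place of 2,3-dichlorophenyl gives no change at the digits printed from compound 1 to compound 3 (within the scatter), which shows that this position tolerates a different chlorine pattern on the phenyl ring with no shift in minimum effective dose beyond the scatter. No supporting measurement bears on this result.

From the compounds shown here alone, the three compounds cover only substituted phenyl groups at this position, so it remains open whether a pyridine ring, a benzyl group or a phenyl ring carrying a methoxy group or a carboxylic acid would move the read-out in this assay. They also leave open whether any change elsewhere on the shared core would do so.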